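Cutting the Aryl Group Back to Phenyl

The compounds below may be only part of what the source reports. "The series", "measured", "known", "first", "only" and "open" are said of these compounds alone.

Two compounds that share the same core but carry different aryl groups have been measured in a functional assay on MCF7 cells (Homo sapiens) for cytotoxicity; a higher number here means a weaker inhibitor, a lower number a stronger inhibitor. Here compound 1 (`C=C/C=C\[C@H](C)[C@H](OC(N)=O)[C@@H](C)[C@H](O)[C@@H](C)C/C(C)=C\[C@H](C)[C@@H](O)[C@@H](C)/C=C\CCc1ccc(Oc2ccccc2)cc1`) gives 10000 nM. In this assay compound 2 (`C=C/C=C\[C@H](C)[C@H](OC(N)=O)[C@@H](C)[C@H](O)[C@@H](C)C/C(C)=C\[C@H](C)[C@@H](O)[C@@H](C)/C=C\CCc1ccc(C)c(O)c1`) gives 4000 nM, the lower of the two numbers, and its gap to compound 1 lies beyond the usual scatter. Compound 2 is therefore the stronger inhibitor of the measured pair.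

Compound 3 (`C=C/C=C\[C@H](C)[C@H](OC(N)=O)[C@@H](C)[C@H](O)[C@@H](C)C/C(C)=C\[C@H](C)[C@@H](O)[C@@H](C)/C=C\CCc1ccccc1`) has not yet been measured. The change is phenyl in place of 3-hydroxy-4-methylphenyl on a saturated chain carbon, two bonds along the chain from a double-bonded chain carbon. Among the measured compounds shown here, no measured pair isolates this change, so the expectation rests on a narrow span of values, from compound 2 at 4000 nM to compound 1 at 10000 nM. A small step of a 1.6-fold higher number from compound 2 to compound 3 (0.21 log units; within the scatter) is expected in this assay, in the direction of a higher number. Compound 3 is estimated at 6500 nM, with an expected range of 2500 nM to 17000 nM.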

Compound 3, half-maximal inhibitory concentration: 560 nM
The estimate for compound 3 lay 12-fold (1.06 log units) above the measured number, and the stated range ends above it.
By their numbers in this assay, from the lowest: compound 3; then compound 2; then compound 1.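

In this assay the bare phenyl group outperforms both substituted aryl groups at this position: the change from 3-hydroxy-4-methylphenyl to phenyl gives a 7.1-fold lower number from compound 2 to compound 3 (0.85 log units; beyond the scatter) and the change of phenoxy to hydrogen on an aromatic carbon gives an 18-fold lower number from compound 1 to compound 3 (1.25 log units; beyond the scatter) with both steps printed as beyond the scatter. The earlier pair held only substituted rings and so could not show that compound 3, with no substituent on its ring, would be the strongest inhibitor of the three, and here both sets of ring substituents go with a higher number than the plain ring. Nothing measured on these compounds accounts for this gain, so the reason for it stays unknown.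

The compounds shown leave open whether the hydroxy group or the methyl group alone accounts for the step from compound 2, since the two leave together in this change. They also leave open how a single fluorine, a methoxy group or a pyridine ring in place of phenyl, or a longer chain leading to the ring, would read in this assay on this core.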